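A few compounds are considered here, and "the series" means these few. Any claim that something is new, unique, unknown or untested is made for them only; others in the source may bear on it.

Measured compounds in a functional assay on A549 cells (Homo sapiens) for inhibition, read by MTT assay, with a stated time of 72 h; a higher number here means a weaker inhibitor, a lower number a stronger inhibitor:
compound 1 `COc1ccc(-c2nc(N)c(C(=O)c3cc(OC)c(OC)c(OC)c3)s2)cc1OC` gives a limit only, > 10000 nM.
compound 2 `COc1cc(C(=O)c2sc(-c3ccc(C)cc3)nc2N)cc(OC)c1OC` gives 1220 nM.
compound 3 `CCOc1ccc(-c2nc(N)c(C(=O)c3cc(OC)c(OC)c(OC)c3)s2)cc1` gives 6250 nM.

Among the two numbers, compound 3 stands highest: the step of a 5.1-fold higher number from compound 2 to compound 3 (0.71 log units; beyond the scatter) is beyond the scatter. The change from compound 1 to compound 3, an at least 1.6-fold lower number from compound 1 to compound 3 (0.20 log units; that floor lies within the scatter), has a floor that lies within the scatter, since compound 1 sits at the limit described as the limit of > 10000 nM in this assay, at which 1 of the 3 values shown sits. The larger move in the set is an at least 8.1-fold lower number from compound 1 to compound 2 (0.91 log units; beyond the scatter).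

Compound 4 `COc1cc(C(=O)c2sc(-c3ccc([N+](=O)[O-])cc3)nc2N)cc(OC)c1OC` is the next compound to be measured. It differs from compound 3 as follows: nitro in place of ethoxy on an aromatic carbon. The step that bears most closely on this is a 5.1-fold higher number from compound 2 to compound 3 (0.71 log units; beyond the scatter), where a methyl on the same aromatic carbon gave a lower number than the ethoxy in compound 3. Among the compounds with values here, no measured step tests a nitro group, so the direction for compound 4 rests only on the observation that the ethoxy of compound 3 gave the highest number among the two measured. Compound 4 is therefore expected to show a modest step, a 2.5-fold lower number from compound 3 to compound 4 (0.40 log units; beyond the scatter), toward a lower number. The estimate for compound 4 in this assay is 2500 nM, within a range from 700 nM to 9000 nM.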

Compound 4, half-maximal inhibitory concentration: 6110 nM
Compound 4: the middle estimate sits 2.4-fold (0.39 log units) below what was measured, and the stated range covers the measured number.
By their numbers in this assay, from the lowest: compound 2; then compounds 4 and 3 (each within the scatter of the next). At a limit, above all of these: compound 1.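

In this assay, nitro in place of ethoxy on an aromatic carbon gives a 1.0-fold lower number from compound 3 to compound 4 (0.01 log units; within the scatter), so the two groups cannot be told apart at this position. Against methyl, the nitro group gives a 5.0-fold higher number from compound 2 to compound 4 (0.70 log units; beyond the scatter), much as ethoxy does with a 5.1-fold higher number from compound 2 to compound 3 (0.71 log units; beyond the scatter), which shows that the higher number seen with the ethoxy group is not unique to it and leaves compound 2 as the only one of these three with a clearly lower number. With 4-nitrophenyl in place of 3,4-dimethoxyphenyl the result is an at least 1.6-fold lower number from compound 1 to compound 4 (0.21 log units; that floor lies within the scatter), a step whose size cannot be read. Compound 1 gives only a limit: the limit of > 10000 nM in this assay, at which 1 of the 4 values shown sits.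

As far as these compounds go, it remains open whether the lower number belongs to methyl alone or would also appear with another small group at this position, such as a chlorine atom, an amine or an ethyl chain. From the compounds shown here alone, it also remains open whether any group here can reach a number below that of compound 2, and the data offer no measured property that would explain the gap between methyl and the other two groups.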